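Para substituent swap at the trifluoromethyl sulfoximine position

The source may hold more compounds than are shown below. What is called first, only, known or untested is meant among the compounds shown, and "the series" means these compounds.

Among the compounds with values here, compound 1 `CC#C[C@H]1CN(S(=O)(=O)c2ccc(N)nc2)CCN1c1ccc(S(=O)(=NC)C(F)(F)F)cc1` carries the trifluoromethyl sulfoximine group, and in an assay on cells (Hepatocyte) for inhibition of glucokinase regulatory protein (Mus musculus), with stated times of 20 min and 40 min (a higher number here means that more compound is needed for the effect, a lower number that less compound is needed), compound 1 gives 2060 nM, the highest of the two numbers measured so far. Compound 2 `CC#C[C@H]1CN(S(=O)(=O)c2ccc(N)nc2)CCN1c1ccc(S(N)(=O)=O)cc1` gives 37 nM in this assay. Within the data shown here, the one step measured, a 56-fold lower number from compound 1 to compound 2 (1.75 log units; beyond the scatter), shows that the shared core tolerates a group with two hydrogen-bond donors at this position with a large drop in the number.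

Compound 3 `CC#C[C@H]1CN(S(=O)(=O)c2ccc(N)nc2)CCN1c1ccc([C@](O)(CO)C(F)(F)F)cc1` is the unmeasured analogue: a group of 8 heavy atoms (3 carbon, 2 oxygen, 3 fluorine; no ring) in place of a group of 8 heavy atoms (2 carbon, 1 nitrogen, 1 oxygen, 3 fluorine, 1 sulfur; no ring), on an aromatic carbon. The entering group again brings two hydrogen-bond donors and two hydrogen-bond acceptors, as does the group of compound 2, though it is a different group, so the step from compound 1 to compound 2 bears on it only as a guide to direction. A lower number is expected in this assay, as a 10-fold lower number from compound 1 to compound 3 (1.01 log units; beyond the scatter), smaller in size than the measured step because compound 2 gave 37 nM with a group not identical to the one entering here. The estimate for compound 3 in this assay is 200 nM, expected to lie between 50 nM and 800 nM.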

Compound 3, half-maximal effective concentration: 98 nM
Estimate against measurement, compound 3: 2.0-fold (0.31 log units) above; low and high end bracket the measured number.
By their numbers in this assay, from the lowest: compound 2; then compound 3; then compound 1.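

In this assay the lower number is not confined to the sulfamoyl group: a 21-fold lower number from compound 1 to compound 3 (1.32 log units; beyond the scatter) comes with 1,2-dihydroxy-1-(trifluoromethyl)ethyl, which contains no sulfur. Compound 3 keeps a trifluoromethyl group, so its presence alone does not go with a number as high as that of compound 1, and a 2.6-fold higher number from compound 2 to compound 3 (0.42 log units; beyond the scatter) places the sulfamoyl group modestly ahead, with a gap beyond the scatter. No measurement at hand gives a reason for either step.

The compounds shown leave open whether both hydroxyl groups of the entering group are required, as a simple hydroxymethyl group or a carboxylic acid at this position would test. They also leave open how the opposite configuration at the defined stereocentre of compound 3 would read in this assay.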